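Amide tail variation on the shared anilinopyrimidine series

The compounds below may be only part of what the source reports. "The series", "measured", "known", "first", "only" and "open" are said of these compounds alone.

Working notes on the series. In a functional assay on KB cells (Homo sapiens) for antiproliferative activity, read by sulforhodamine B assay, with a stated time of 3 days (on this read-out higher numbers stand for weaker inhibition of growth and lower numbers for stronger inhibition of growth), compound 1 `COc1ccc(N2CCN(C)CC2)cc1Nc1ncc(F)c(Nc2ccc(F)cc2)n1` gives 960 nM and compound 3 `CN1CCC(C(=O)Nc2cccc(Nc3ncc(F)c(Nc4ccc(F)cc4)n3)c2)CC1` gives 1700 nM, the two numbers lying within the scatter of each other, so neither is to be ranked above the other. Compound 2 `O=C(Nc1ccc(C(F)(F)F)cc1)c1cccc(Nc2ncc(F)c(Nc3ccc(F)cc3)n2)c1` reaches only the limit of this assay, > 10000 nM, as noted in the limit of > 10000 nM in this assay, at which 1 of the 3 values shown sits. Among the measured compounds shown here, no measured step between two compounds differing in one place is available.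

Compound 4 `CN(C)CC(=O)Nc1cccc(Nc2ncc(F)c(Nc3ccc(F)cc3)n2)c1` differs from compound 3 by (dimethylamino)methyl in place of 1-methylpiperidin-4-yl on a carbonyl carbon. Both compound 3 and compound 4 carry an amide bearing a basic amine, so the step of a 1.5-fold higher number from compound 3 to compound 4 (0.17 log units; within the scatter) is expected to stay near or slightly beyond the scatter, towards weaker inhibition. Compound 4 is estimated at 2500 nM, with a range from 800 nM to 8000 nM.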

Compound 4, concentration for 50% growth inhibition: 1260 nM
Compound 4: middle estimate off by 2.0-fold (0.30 log units), on the high side; measured number inside the range.
By their numbers in this assay, from the lowest: compounds 1, 4 and 3 (each within the scatter of the next). At a limit, above all of these: compound 2.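

In this assay, among the compounds shown here, the exchange of 1-methylpiperidin-4-yl for (dimethylamino)methyl on a carbonyl carbon gives the only measured step at this position (a 1.3-fold lower number from compound 3 to compound 4 (0.13 log units; within the scatter)), and that step lies within the scatter. Losing the six-membered non-aromatic ring and going to an open group with fewer heavy atoms therefore leaves compound 3 and compound 4 unranked. Nothing measured here accounts for this step.

Still open, on these data alone, is how an unsubstituted methyl or a carboxylic acid would read on the same carbonyl carbon. As far as these compounds go, a longer chain ending in the dimethylamino group also remains open.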